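Cytotoxicity notes: change at the ring nitrogen, compound 3 to 4

The compounds below may be only part of what the source reports. "The series", "measured", "known", "first", "only" and "open" are said of these compounds alone.

Measured so far:
Compound 1, `Cc1cc(/C=C2\SC(=S)N(c3ccccc3)C2=O)c(C)n1-c1cccc(-c2nnn[nH]2)c1`: in an ADME assay on MT2 cells (Homo sapiens) for cytotoxicity, read by XTT assay, with a stated time of 4 days (a higher number here means that more compound is tolerated, a lower number that less compound is tolerated), compound 1 gives 61000 nM.
Compound 2, `Cc1cc(/C=C2\SC(=S)N(c3cccc(Br)c3)C2=O)c(C)n1-c1cccc(-c2nnn[nH]2)c1`: in this assay compound 2 gives 22600 nM.
Compound 3, `Cc1cc(/C=C2\SC(=S)N(c3cccc([N+](=O)[O-])c3)C2=O)c(C)n1-c1cccc(-c2nnn[nH]2)c1`: in this assay compound 3 gives 77000 nM.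

Compound 3 holds the highest number of the three, but its gap to compound 1 is within the scatter (a 1.3-fold higher number from compound 1 to compound 3 (0.10 log units; within the scatter)); only its gap to compound 2 is beyond it (a 3.4-fold higher number from compound 2 to compound 3 (0.53 log units; beyond the scatter)). Compound 4, `Cc1cc(/C=C2\SC(=S)N(Cc3ccccc3)C2=O)c(C)n1-c1cccc(-c2nnn[nH]2)c1`, is the next member. The change from compound 3: benzyl in place of 3-nitrophenyl on an amide-type nitrogen in a ring.

For the measured compounds named here, no measured step makes an exchange of this kind; the three steps available alter only a substituent on an aromatic carbon of the group on the ring nitrogen. They were small to modest: a 2.7-fold lower number from compound 1 to compound 2 (0.43 log units; beyond the scatter), a 1.3-fold higher number from compound 1 to compound 3 (0.10 log units; within the scatter) and a 3.4-fold higher number from compound 2 to compound 3 (0.53 log units; beyond the scatter). Taken together they show the number moving over a modest span in either direction when this group is varied, and nothing points to a larger movement for a larger change. On these data alone, for compound 4 a modestly lower number than for compound 3 is expected, a 1.5-fold lower number from compound 3 to compound 4 (0.19 log units; within the scatter), landing inside the span already seen, with wide uncertainty since the exchange is untested. The estimate for compound 4 is 50000 nM, with a range from 20000 nM to 120000 nM.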

Compound 4, half-maximal cytotoxic concentration: 150000 nM
Compound 4: the middle estimate sits 3.0-fold (0.48 log units) below what was measured; the measured number lies above the stated range.
By their numbers in this assay, from the lowest: compound 2; then compounds 1, 3 and 4 (each within the scatter of the next, the first and the last beyond it).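

Benzyl on the amide-type nitrogen in a ring is tolerated in this assay, and the plainest comparison is with the unsubstituted phenyl of compound 1 (a 2.5-fold higher number from compound 1 to compound 4 (0.39 log units; beyond the scatter)), a step that leaves the scatter. The comparison with 3-nitrophenyl stays inside the scatter (a 1.9-fold higher number from compound 3 to compound 4 (0.29 log units; within the scatter)), so benzyl and 3-nitrophenyl cannot be told apart here, whereas the comparison with 3-bromophenyl gives the widest step in the set so far (a 6.6-fold higher number from compound 2 to compound 4 (0.82 log units; beyond the scatter)). The position therefore accepts more than a substituent swap on a phenyl ring, and the group with an aromatic ring of carbon only and no hydrogen-bond acceptors sits with the 3-nitrophenyl compound at the top of the series, but nothing available bears on why the number moves at this position.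

Open, on these data alone, is whether the bromo substituent, which lowers the number on the phenyl ring, would do the same on the ring of the benzyl group, or whether a nitro group there would stay as neutral as it does on phenyl. Also open, as far as these compounds go, is how a longer chain such as phenethyl, a plain alkyl chain with no ring, or a benzyl carrying an amine or a carboxylic acid would read in this assay at this nitrogen.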